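The source may hold more compounds than are shown below. What is called first, only, known or untested is meant among the compounds shown, and "the series" means these compounds.

Measured so far in an ADME assay on HEK293 cells (Homo sapiens) for cytotoxicity, read by MTT assay, with a stated time of 36 h; on this read-out lower numbers stand for stronger inhibition and higher numbers for weaker inhibition:
- compound 1, `O=C(c1ccc2c(c1)OCCO2)C1CCN(Cc2coc(-c3ccc(Cl)cc3)n2)CC1`, gives > 150 ug/mL, which is a limit of the assay.
- compound 2, `O=C(c1ccc2c(c1)OCCO2)C1CCN(Cc2coc(-c3ccccc3)n2)CC1`, gives > 150 ug/mL, also a limit.
- compound 3, `O=C(c1ccc2c(c1)OCCO2)C1CCN(Cc2coc(-c3cccc(F)c3)n2)CC1`, gives > 150 ug/mL, again a limit.

Compound 1 thus stands only at a limit in this assay, without a number of its own. Compound 4, `Cc1ccc(-c2nc(CN3CCC(C(=O)c4ccc5c(c4)OCCO5)CC3)co2)cc1`, differs from it in one place: methyl in place of chloro on an aromatic carbon. The measured steps that bear on this change are those on the same ring: a step that the two limits leave unreadable from compound 1 to compound 2, a step that the two limits leave unreadable from compound 1 to compound 3 and a step that the two limits leave unreadable from compound 2 to compound 3. All three rest on (the limit of > 150 ug/mL in this assay, at which 3 of the 3 values shown sit), so no size can be read from any of them. No step beyond the scatter is therefore expected in this assay. Compound 4 is estimated at 200 ug/mL, with a range from 100 ug/mL to 400 ug/mL. The step that the limit leaves unreadable from compound 1 to compound 4 that this estimate implies is expected to be small.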

Compound 4, half-maximal inhibitory concentration: > 150 ug/mL
Compound 4 ended at the assay's limit (the forecaster's own chance of this, stated with the estimate: 85%); the middle value lies beyond the limit too.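

No step can be read between compound 4 and compounds 1, 2 or 3, since all four sit at the same limit in this assay: the limit of > 150 ug/mL in this assay, at which 4 of the 4 values shown sit.

Going by these compounds, how far apart these compounds truly lie in this assay remains open, as does any effect of the ring substituents.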